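Cytotoxicity notes: one fluoro removed from compound 1

The source may report more compounds than this note shows. Statements on the series, on what has been measured and on what is new or still open speak of the compounds shown alone.

compound 1 `CC(C)n1ncc2c(C(=O)Nc3cccc(F)c3F)cc(-c3cccs3)nc21` — this assay: 75000 nM
compound 2 `CC(C)n1ncc2c(C(=O)Nc3ccc(F)cc3)cc(-c3ccsc3)nc21` — this assay: > 200000 nM

For the measured compounds named here, in an ADME assay on LLC-MK2 cells (Macaca mulatta) for cytotoxicity, read by spectrophotometry and crystal violet staining, with a stated time of 4 days (on this read-out higher numbers stand for lower toxicity in this test and lower numbers for higher toxicity in this test), compound 1 gives 75000 nM and holds the only number in the set. Compound 2 gives > 200000 nM, which is a limit of the assay and not a number. the limit of > 200000 nM in this assay, at which 1 of the 2 values shown sits, marks that reading. Going by the values given here, compound 2 and compound 1 are not linked by a single change, so no step between them is measured.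

Compound 3 `CC(C)n1ncc2c(C(=O)Nc3ccccc3F)cc(-c3cccs3)nc21` differs from compound 1 by hydrogen in place of fluoro on an aromatic carbon. Among the compounds with values here, no measured pair carries this change, so its effect in this assay is unknown. The step from compound 1 to compound 3 is expected to be small, a 1.3-fold higher number from compound 1 to compound 3 (0.12 log units; within the scatter), at most a modest move toward lower toxicity and possibly none beyond the scatter. Compound 3 is therefore estimated at 100000 nM, within a range from 40000 nM to 250000 nM.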

Compound 3, half-maximal cytotoxic concentration: 50000 nM
Compound 3: the middle estimate sits 2.0-fold (0.30 log units) above what was measured, and the stated range covers the measured number.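

In this assay, hydrogen in place of fluoro on an aromatic carbon, the change from 2,3-difluorophenyl to 2-fluorophenyl, gives a 1.5-fold lower number from compound 1 to compound 3 (0.18 log units; within the scatter). For the compounds shown here, this is the first step in the set that isolates a single place, and it shows that this fluoro can leave without a move beyond the scatter, so the reading of compound 1 does not depend on it. Nothing available accounts for the size of this step.

Still open, going by these compounds, is whether a different group at this position, such as methoxy, an amine or a carboxylic acid, would shift the reading beyond the scatter. Also open, on these data alone, is what separates compound 2, whose reading is a limit of the assay, from compound 1 and compound 3, since it differs from each in more than one place.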